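The compounds below may be only part of what the source reports. "The series", "measured", "known", "first", "only" and "open" are said of these compounds alone.

Going by the values given here, compound 2 `CC1(C)CCC[C@]2(C)[C@@H](CC[C@@](C)(O)/C=C/c3ccc(Cl)nc3)[C@](C)(O)CC[C@@H]12` is one of two compounds measured in a functional assay on A549 cells (Homo sapiens) for cytotoxicity, read by MTT assay, with a stated time of 48 h (on this read-out lower numbers stand for stronger inhibition and higher numbers for weaker inhibition), where compound 2 gives 3280 nM. Compound 1 `Cc1ccc(C)c(/C=C/[C@](C)(O)CC[C@@H]2[C@@]3(C)CCCC(C)(C)[C@@H]3CC[C@@]2(C)O)c1` gives 3320 nM in this assay, and the step of a 1.0-fold lower number from compound 1 to compound 2 (0.01 log units; within the scatter) shows that the two numbers lie within the scatter of each other, so neither stands apart from the other. Compound 3 `CC1(C)CCC[C@]2(C)[C@@H](CC[C@@](C)(O)/C=C/c3ccc(F)cc3)[C@](C)(O)CC[C@@H]12` has not yet been measured. It differs from compound 2 in one place: 4-fluorophenyl in place of 6-chloropyridin-3-yl on a double-bonded chain carbon bound to a double-bonded chain carbon. Among the compounds with values here, the only measured step that bears on this change is a 1.0-fold lower number from compound 1 to compound 2 (0.01 log units; within the scatter), an exchange of one aromatic ring for another at the same place that left the number essentially unchanged. On that basis no step beyond the scatter is expected in this assay, in either direction. The estimate for compound 3 in this assay is 3300 nM, with a range from 1600 nM to 6800 nM. The expected step of a 1.0-fold higher number from compound 2 to compound 3 (0.00 log units; within the scatter) is accordingly a flat one.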

Compound 3, half-maximal inhibitory concentration: 3100 nM
Beside the measured number, compound 3's estimate is 1.1-fold (0.03 log units) above it; measured number inside the range.
By their numbers in this assay, from the lowest: compounds 3, 2 and 1 (each within the scatter of the next).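

In this assay the exchange of rings gives a 1.1-fold lower number from compound 2 to compound 3 (0.02 log units; within the scatter) and, set against the 2,5-dimethylphenyl ring, gives a 1.1-fold lower number from compound 1 to compound 3 (0.03 log units; within the scatter) as well, so a third aromatic ring on this double-bonded chain carbon also leaves the number flat. The hydrogen-bond acceptor of 6-chloropyridin-3-yl is absent from 4-fluorophenyl, and the number still stays within the scatter, so a ring of carbon only and a ring with a hetero atom cannot be told apart here. Nothing available explains this flat picture. On these data alone, all three compounds carry an aromatic ring at this place, so it remains open whether a different kind of group, such as an amine, a carboxylic acid or a longer chain, would move the number beyond the scatter. As far as these compounds go, it also remains open whether any such step would appear on other cells.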